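Same Atoms, Joined Differently: A Step Towards Compound 4

The source may report more compounds than this note shows. Statements on the series, on what has been measured and on what is new or still open speak of the compounds shown alone.

In a functional assay on MCF7 cells (Homo sapiens) for inhibition, read by fluorescence, with a stated time of 72 h (a higher number here means a weaker inhibitor, a lower number a stronger inhibitor), compound 1 `CC(C)n1cnc2c(NC(=N)N)nc(NCCCO)nc21` gives 8800 nM. Compound 2 `CC(C)[C@@H](N)COc1nc(NC(=N)N)c2ncn(C(C)C)c2n1`, with 2-amino-3-methylbutoxy on the same aromatic carbon, gives 79400 nM. Compound 3 `CC(C)n1cnc2c(NC(=N)N)nc(OC[C@H]3CCCN3)nc21`, which carries (pyrrolidin-2-yl)methoxy there, gives > 100000 nM. That value is a limit of the assay and not a number.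

Compound 4 `CC(C)n1cnc2c(NC(=N)N)nc(N3CCC[C@@H]3CO)nc21` is still unmeasured. It has the same atoms as compound 3, joined differently, with 2-(hydroxymethyl)pyrrolidin-1-yl in place of (pyrrolidin-2-yl)methoxy on an aromatic carbon.

Going by the values given here, three measured steps bear on this change. Replacing the (3-hydroxypropyl)amino group gave a 9.0-fold higher number from compound 1 to compound 2 (0.96 log units; beyond the scatter), a modest step, and an at least 11-fold higher number from compound 1 to compound 3 (1.05 log units; beyond the scatter), a large one. The third, an at least 1.2-fold higher number from compound 2 to compound 3 (0.10 log units; that floor lies within the scatter), says little, since its floor lies within the scatter. Among these three compounds, the two groups ending in "oxy" both sit on the weaker side of the one ending in "amino". Compound 4 also has a hydroxy-bearing group without that ending, so it should move back towards compound 1 at 8800 nM, though probably not all the way. The expected change is an at least 5.0-fold lower number from compound 3 to compound 4 (0.69 log units; beyond the scatter), a step to a lower number and so to stronger inhibition. Compound 4 is expected at about 20000 nM, with an estimated range of 5000 nM to 80000 nM.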

Compound 4, half-maximal inhibitory concentration: 20400 nM
Compound 4: the middle estimate sits 1.0-fold (0.01 log units) below what was measured, within the range that was stated.
By their numbers in this assay, from the lowest: compound 1; then compound 4; then compound 2. At a limit, above all of these: compound 3.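

With the atoms unchanged, joining the side group to the aromatic carbon through its ring nitrogen rather than through its oxygen gives an at least 4.9-fold lower number from compound 3 to compound 4 (0.69 log units; beyond the scatter). The value of compound 3 is a limit of the assay and not a number, so the size of that step is only a floor: the limit of > 100000 nM in this assay, at which 1 of the 4 values shown sits. Among these four compounds, with no exception, the two groups joined through nitrogen lie lower than the two joined through oxygen: the new group gives a 3.9-fold lower number from compound 2 to compound 4 (0.59 log units; beyond the scatter), while a 2.3-fold higher number from compound 1 to compound 4 (0.37 log units; beyond the scatter) shows that a nitrogen link alone does not bring it level with the (3-hydroxypropyl)amino group.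

Going by these compounds, it remains open whether the hydroxy group of 2-(hydroxymethyl)pyrrolidin-1-yl contributes to this result at all, a question that a plain pyrrolidin-1-yl group at the same aromatic carbon would address. Also open, on these data alone, is how this assay would read a nitrogen-joined ring carrying a carboxylic acid in place of the hydroxymethyl, or a longer chain ending in the same hydroxy group.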